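Third fluoro on the aryloxy ring of compound 2

The source may report more compounds than this note shows. Statements on the series, on what has been measured and on what is new or still open speak of the compounds shown alone.

Measured so far:
- compound 1, `Cc1cc(COc2ccc(F)cc2)nc(-c2ccccn2)n1`: 631 nM
- compound 2, `Cc1cc(COc2ccc(F)cc2F)nc(-c2ccccn2)n1`: 398 nM
- compound 3, `Cc1cc(COc2cc(F)c(F)cc2F)nc(-c2ccccn2)n1`: 398 nM

All three share one core and differ only in the fluoro count on the phenoxy ring. In a functional assay on cells for antagonist activity at Free fatty acid receptor 1 (Homo sapiens), read by TR-FRET and inositol phosphate accumulation, with a stated time of 2 h (on this read-out higher numbers stand for weaker inhibition and lower numbers for stronger inhibition), compound 2 stands level with compound 3 and the two together give the lowest numbers of the three; its nearest neighbour is compound 3, with no change at the digits printed from compound 2 to compound 3 (within the scatter), and its furthest is compound 1, reached by a 1.6-fold lower number from compound 1 to compound 2 (0.20 log units; within the scatter).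

Compound 4, `Cc1cc(COc2c(F)cc(F)cc2F)nc(-c2ccccn2)n1`, is not yet measured. Against compound 2 the change is fluoro in place of hydrogen on an aromatic carbon, on an aromatic carbon of a six-membered aromatic ring of carbon only, ortho to a large group and meta to two fluoro groups.

The two measured steps of the same kind on this ring, a 1.6-fold lower number from compound 1 to compound 2 (0.20 log units; within the scatter) and no change at the digits printed from compound 2 to compound 3 (within the scatter), both fall within the scatter. On that basis no step beyond the scatter is expected in this assay for a further fluoro in place of hydrogen here; the estimated step is a 1.0-fold higher number from compound 2 to compound 4 (0.00 log units; within the scatter). Compound 4 is therefore expected to give about 400 nM, within a range of 200 nM to 800 nM.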

Compound 4, half-maximal inhibitory concentration in the Free fatty acid receptor 1 assay: 1260 nM
Compound 4: the middle estimate sits 3.2-fold (0.50 log units) below what was measured; measured number above the stated range.
By their numbers in the Free fatty acid receptor 1 assay, from the lowest: compounds 2, 3, 1 and 4 (each within the scatter of the next, the first and the last beyond it).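

Within the data shown here, in the Free fatty acid receptor 1 assay, compound 2 gives 398 nM and compound 4 gives 1260 nM; this is the first fluoro in place of hydrogen on this ring to give a step beyond the scatter, a 3.2-fold higher number from compound 2 to compound 4 (0.50 log units; beyond the scatter), and the step is towards weaker inhibition. The same replacement at another carbon of this ring gives, in the Free fatty acid receptor 1 assay, no change at the digits printed from compound 2 to compound 3 (within the scatter), so among these compounds the outcome follows the place of the added fluoro and not the fluoro count alone, with the step appearing on the carbon ortho to a large group and meta to two fluoro groups. In a physicochemical assay for lipophilicity, at pH 7.4 (a higher number here means a more lipophilic compound, a lower number a more polar compound), compound 2 gives 3.1 and compound 4 gives 3.2. In the physicochemical assay the same pair gives a number 0.10 log units higher from compound 2 to compound 4 (within the scatter), so the step in inhibition comes without a step beyond the scatter in the distribution coefficient.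

The data shown offer nothing that accounts for the loss at this carbon. Also open, as far as these compounds go, is whether the step belongs to fluoro in particular or to any replacement of hydrogen at this carbon, a question that chloro, methyl or methoxy in the same place would address, and whether the step persists when this carbon carries fluoro but the other ring fluoro groups are absent.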